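The source may hold more compounds than are shown below. What is called first, only, known or untested is meant among the compounds shown, and "the series" means these compounds.

Measured so far in a physicochemical assay for solubility, with a stated time of 18 h, at pH 7.4; on this read-out lower numbers stand for lower solubility and higher numbers for higher solubility:
- compound 1 `COc1cccc(CNCCCNc2ccnc3cc(Cc4ccc(F)cc4)ccc23)c1O` gives 4200 nM
- compound 2 `COc1cccc(CNCCCNc2ccnc3cc(Oc4ccc(C(C)(C)C)cc4)ccc23)c1O` gives 14500 nM

Among the compounds with values here, compound 2 stands highest of the two numbers in this assay; the single measured step, a 3.5-fold higher number from compound 1 to compound 2 (0.54 log units; beyond the scatter), separates it from compound 1. Compound 3 `COc1cccc(CNCCCNc2ccnc3cc(Cc4cc(C)cc(C)c4)ccc23)c1O` differs from compound 2 by 3,5-dimethylbenzyl in place of 4-(tert-butyl)phenoxy on an aromatic carbon. That earlier step bears on this change only in part, as it too swapped a benzyl against a phenoxy group; a modest step downward, back toward compound 1, is therefore expected. The estimate for compound 3 is 5000 nM, range 1500 nM to 15000 nM, which is expected to mean a 2.9-fold lower number from compound 2 to compound 3 (0.46 log units; beyond the scatter).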

Compound 3, solubility: 4200 nM
The estimate for compound 3 lay 1.2-fold (0.08 log units) above the measured number; the measured number falls inside the stated range.
By their numbers in this assay, from the lowest: compounds 1 and 3 (each within the scatter of the next); then compound 2.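

In this assay the change at this aromatic carbon gives a 3.5-fold lower number from compound 2 to compound 3 (0.54 log units; beyond the scatter) on going to 3,5-dimethylbenzyl, so this benzyl group does not keep the higher number. Between the two benzyl compounds the change gives no change at the digits printed from compound 1 to compound 3 (within the scatter) here, so 3,5-dimethylphenyl and 4-fluorophenyl are not told apart. No measurement at hand speaks to the reason for these steps.

As far as these compounds go, whether the higher number of compound 2 goes with the ether oxygen or with the tert-butyl group stays open, since the two enter together. A 4-(tert-butyl)benzyl or 4-fluorophenoxy group would separate them, and an amine or carboxylic acid on the ring remains untested in the compounds shown.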